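A few compounds are considered here, and "the series" means these few. Any claim that something is new, unique, unknown or untested is made for them only; others in the source may bear on it.

The series shares a carbamate-bearing core with a para substituent on the aromatic ring. Compound 1 `C=C1C(=O)OC[C@H]1CCOC(=O)Nc1ccc(C(C)C)cc1` gives 12400 nM in an ADME assay on RAW264.7 cells (Mus musculus) for cytotoxicity, read by MTT assay, with a stated time of 18 h; a lower number here means that less compound is tolerated, a higher number that more compound is tolerated. Compound 2 `C=C1C(=O)OC[C@@H]1CCOC(=O)Nc1ccc(C(C)C)cc1` gives 15300 nM in this assay, and compound 3 `C=C1C(=O)OC[C@H]1CCOC(=O)Nc1ccc(OC)cc1` gives 12400 nM in this assay. All three numbers sit within the scatter of one another, so compound 2 cannot be set apart from compound 1 or compound 3. The step of a 1.2-fold higher number from compound 1 to compound 2 (0.09 log units; within the scatter) rests on (the fact that compounds 1 and 2 differ only in the configuration as drawn), and the step of no change at the digits printed from compound 1 to compound 3 (within the scatter) shows that exchanging the para group does not move the number either.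

Compound 4 `C=C1C(=O)OC[C@@H]1CCOC(=O)Nc1ccc(CCCC)cc1` is not yet measured. It differs from compound 2 by butyl in place of isopropyl on an aromatic carbon. Going by the values given here, the only step bearing on a change at that position, from compound 1 to compound 3, stayed within the scatter, and no measured step probes a longer chain. Compound 4 is therefore expected to show little beyond the scatter in this assay, with the estimated step of a 1.3-fold lower number from compound 2 to compound 4 (0.11 log units; within the scatter). The estimate for compound 4 is 12000 nM, ranging from 5500 nM to 28000 nM.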

Compound 4, half-maximal cytotoxic concentration: 9950 nM
Estimate against measurement, compound 4: 1.2-fold (0.08 log units) above; measured number inside the range.
By their numbers in this assay, from the lowest: compounds 4, 1, 3 and 2 (each within the scatter of the next).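

In this assay, butyl in place of isopropyl at this position gives a 1.5-fold lower number from compound 2 to compound 4 (0.19 log units; within the scatter), so this change, like the earlier exchange for methoxy, stays within the scatter. The earlier compounds shown here had probed this position only in the configuration of compound 1 and only with methoxy, whereas this step extends the observation to a four-carbon chain in the configuration of compound 2. Nothing known about these compounds accounts for the size of this step.

From the compounds shown here alone, whether a chain longer than butyl, an amine or a carboxylic acid at this position would also stay within the scatter remains open, as does the reading for butyl in the configuration of compound 1. The compounds shown also leave the shared core and the carbamate unvaried, so the part these play in the numbers cannot be told.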